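The compounds below may be only part of what the source reports. "The series", "measured", "known", "first", "only" and "open" are said of these compounds alone.

Working notes on the series. Compound 1, `CONC(=O)c1ccc(N(Cc2ccc(C3CCCCC3)cn2)C(=O)[C@H]2CCN2S(=O)(=O)c2c(F)c(F)c(F)c(F)c2F)c(F)c1`, carries a 2-fluoro-4-(methoxycarbamoyl)phenyl group on the amide-type nitrogen of the shared core; in a functional assay on MDA-MB-231 cells (Homo sapiens) for antiproliferative activity, with a stated time of 72 h (a lower number here means that less compound is needed, a higher number that more compound is needed for the effect), compound 1 gives "not determined" (no result reported), so there is no number from which a step can be counted. Compound 2, `O=C([C@H]1CCN1S(=O)(=O)c1c(F)c(F)c(F)c(F)c1F)N(Cc1cnc(C2CCCCC2)cn1)c1ccc2c(=O)[nH]cnc2c1`, has a different pyrazine-derived chain and a bicyclic aryl group on the same nitrogen; in this assay compound 2 gives 4200 nM. Within the data shown here, no step between measured compounds is available, and compound 2 differs from compound 1 in more than one place, so its value serves only as a rough point of reference.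

Compound 3, `O=C1NC(=O)c2cc(N(Cc3ccc(C4CCCCC4)cn3)C(=O)[C@H]3CCN3S(=O)(=O)c3c(F)c(F)c(F)c(F)c3F)ccc21`, is the unmeasured analogue of compound 1 with the change (a group of 11 heavy atoms (8 carbon, 1 nitrogen, 2 oxygen; one five-membered non-aromatic ring with 1 hetero atom, one six-membered aromatic ring of carbon only) in place of a group of 12 heavy atoms (8 carbon, 1 nitrogen, 2 oxygen, 1 fluorine; one six-membered aromatic ring of carbon only), on an amide-type nitrogen). Since compound 1 has no value, the size and direction of the step cannot be stated; the expectation rests only on compound 2, whose group on that nitrogen also contains a ring fused to a six-membered aromatic ring, and on its value of 4200 nM. Compound 3 is therefore expected to fall near 3500 nM, with a plausible range of 900 nM to 14000 nM.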

Compound 3, half-maximal effective concentration: 1700 nM
Beside the measured number, compound 3's estimate is 2.1-fold (0.31 log units) above it; measured number inside the range.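

In this assay, among these compounds, compound 1 gives "not determined" (no result reported) and compound 3 gives 1700 nM, so no step between compound 1 and compound 3 can be read. The compounds shown leave open how replacing the 2-fluoro-4-(methoxycarbamoyl)phenyl group on the amide-type nitrogen changes the value. No supporting evidence bears on the result of compound 3.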